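The source may hold more compounds than are shown below. What is called first, only, known or untested is meant among the compounds shown, and "the series" means these compounds.

Measured compounds:
Compound 1 `O=c1c2ccccc2[se]n1-c1nnc(-c2ccccc2Cl)s1` in a functional assay on A549 cells (Homo sapiens) for antiproliferative activity, read by CCK-8 assay, with a stated time of 48 h (a lower number here means a stronger inhibitor, a higher number a weaker inhibitor), gives 10100 nM.
Compound 2 `Cc1cccc(-c2nnc(-n3[se]c4ccccc4c3=O)s2)c1` in this assay gives 14800 nM.

Compound 1 holds the lowest of the two numbers, but its nearest neighbour, compound 2, sits close: the step of a 1.5-fold higher number from compound 1 to compound 2 (0.17 log units; within the scatter) lies within the usual scatter, so the two cannot be ranked against each other.

Compound 3 `COc1ccccc1-c1nnc(-n2[se]c3ccccc3c2=O)s1` has not yet been measured in this assay. It differs from compound 1 in one place: methoxy in place of chloro on an aromatic carbon, the place being described as ortho to a large group. Going by the values given here, only one measured step bears on this change, the exchange of the whole aryl group that turned compound 1 into compound 2, and that step stayed inside the scatter. Among the compounds with values here, no measured step shows what a methoxy group does at this position, so the expectation rests on the single comparison available. On that basis the step from compound 1 to compound 3 is expected to be a 1.2-fold higher number from compound 1 to compound 3 (0.07 log units; within the scatter), with no direction beyond the scatter. Compound 3 is therefore estimated at 12000 nM in this assay, with a range from 4000 nM to 36000 nM.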

Compound 3, half-maximal inhibitory concentration: 3120 nM
Beside the measured number, compound 3's estimate is 3.8-fold (0.59 log units) above it; the measured number lies below the stated range.
By their numbers in this assay, from the lowest: compound 3; then compounds 1 and 2 (each within the scatter of the next).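

In this assay, going by these compounds alone, the exchange of chloro for methoxy on an aromatic carbon ortho to a large group gives a 3.2-fold lower number from compound 1 to compound 3 (0.51 log units; beyond the scatter) and so provides the first step in this set that lies beyond the scatter, though a modest one. The earlier pair showed only a change of substituted phenyl group that could not be told from the scatter, whereas this result shows that the number can respond to what stands at this one place on the ring. The change swaps a single chlorine for a methoxy carrying one hydrogen-bond acceptor, but nothing available explains the lower number, and no measurement here bears on its cause.

The compounds shown leave open whether this lower number belongs to methoxy in particular or would also appear with a hydroxyl, an amine or a longer chain such as ethoxy on the same carbon. They also leave open whether a methoxy group placed elsewhere on this ring, or a second methoxy group, would move the number in the same direction.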